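Swapping chloro for methyl on a potent growth inhibitor

The source may report more compounds than this note shows. Statements on the series, on what has been measured and on what is new or still open speak of the compounds shown alone.

Measured so far in a functional assay on MDA-N cells (Homo sapiens) for antiproliferative activity; a lower number here means a stronger inhibitor of growth, a higher number a weaker inhibitor of growth:
- compound 1 `Cc1cccc(-c2cc(O)c3ccc(C)nc3n2)c1`: 31.6 nM
- compound 2 `Cc1cc(C)c2c(O)cc(-c3cccc(F)c3)nc2n1`: 12.9 nM
- compound 3 `Cc1cc(C)c2c(O)cc(-c3cccc(Cl)c3)nc2n1`: 19.1 nM

In this assay, compound 3 gives 19.1 nM. That is the middle of the three numbers, and it lies within the usual scatter of both compound 2 and compound 1.

The next compound is compound 4 `Cc1cccc(-c2cc(O)c3c(C)cc(C)nc3n2)c1`, which has methyl in place of chloro on an aromatic carbon, meta to a large group: methyl in place of chloro on an aromatic carbon.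

For the measured compounds named here, only one measured step touches this place on the ring. It is a 1.5-fold higher number from compound 2 to compound 3 (0.17 log units; within the scatter), where chloro replaces fluoro, and it stays within the scatter. That step exchanges one halogen for another, so it only hints at how a methyl might behave. Going by the values given here, no pair of compounds here compares methyl with a halogen on the same core.

Compound 1 offers a second clue, since it carries the same methyl-bearing ring on a different core and gives 31.6 nM. That value also lies within the scatter of compound 3.

Together these point to no step beyond the scatter, in either direction. The estimated change is a 1.0-fold higher number from compound 3 to compound 4 (0.02 log units; within the scatter). For compound 4 the expected value is 20 nM. The estimated range for compound 4 runs from 9 nM to 45 nM.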

Compound 4, concentration for 50% growth inhibition: 20900 nM
Compound 4: the middle estimate sits 1000-fold (3.02 log units) below what was measured, and the stated range ends below it.
By their numbers in this assay, from the lowest: compounds 2, 3 and 1 (each within the scatter of the next, the first and the last beyond it); then compound 4.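

Placing methyl where the halogen stood on the shared core gives a 1100-fold higher number from compound 3 to compound 4 (3.04 log units; beyond the scatter) and a 1600-fold higher number from compound 2 to compound 4 (3.21 log units; beyond the scatter) in this assay, so on this core a methyl group cannot be treated as a stand-in for chloro or fluoro, even though the two halogens themselves stay within the scatter of each other. The methyl on this ring is not poorly tolerated everywhere: compound 1 carries it on its own core and gives 31.6 nM, yet adding one further methyl to that core gives a 660-fold higher number from compound 1 to compound 4 (2.82 log units; beyond the scatter), so among these four compounds the large loss appears only where the two methyl groups occur together. Nothing given here explains why the two methyl groups behave so differently together than apart.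

The compounds shown leave open whether the loss is specific to methyl at this place or would also occur with a larger group such as ethyl or methoxy on the same core. They also leave open whether a hydrogen at this place, with the rest of compound 4 unchanged, would keep the strong growth inhibition of compound 2 and compound 3.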